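The source may report more compounds than this note shows. Statements on the series, on what has been measured and on what is new or still open speak of the compounds shown alone.

Compound 1 `COC(=O)Nc1c(N)nc(-c2nn(Cc3ccccc3F)c3ncccc23)nc1N` gives 0.3 uM in an assay on cells for activation of Guanylate cyclase soluble subunit alpha-1 (Rattus norvegicus), read by cGMP accumulation and immunoassay, with a stated time of 10 min; a higher number here means that more compound is needed for the effect, a lower number that less compound is needed. Compound 2 `Nc1nc(-c2nn(Cc3ccccc3F)c3ncccc23)nc(N)c1N1C[C@H](C(F)(F)F)OC1=O` gives 0.2 uM in this assay.

Among the measured compounds shown here, compound 2 has the lowest of the two numbers; its only neighbour is compound 1, and the step of a 1.5-fold lower number from compound 1 to compound 2 (0.18 log units; within the scatter) stays within the scatter. Compound 3 `Nc1nc(-c2nn(Cc3ccccc3F)c3ncccc23)nc(N)c1N1C[C@@H](C(F)(F)F)OC1=O` differs from compound 2 as follows: the two compounds have the same atoms and bonds and differ only in configuration as drawn: 1 of 1 stereo elements differ; a stereocentre at a saturated ring carbon is drawn R in compound 2 and S in compound 3. For the measured compounds named here, no measured step bears on a change of configuration alone, so no direction beyond the scatter can be expected, though a wider range is allowed for it. Compound 3 is expected at 0.5 uM, between 0.1 uM and 3 uM; this is an estimated step of a 2.5-fold higher number from compound 2 to compound 3 (0.40 log units; beyond the scatter).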

Compound 3, minimum effective concentration: 0.03 uM
Beside the measured number, compound 3's estimate is 17-fold (1.22 log units) above it; the measured number lies below the stated range.
By their numbers in this assay, from the lowest: compound 3; then compounds 2 and 1 (each within the scatter of the next).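

In this assay, the stereocentre at the saturated ring carbon carries real weight, with a 6.7-fold lower number from compound 2 to compound 3 (0.82 log units; beyond the scatter). The replacement of (methoxycarbonyl)amino by 2-oxo-5-(trifluoromethyl)-1,3-oxazolidin-3-yl, which had stayed within the scatter with the R drawing, now reaches a 10-fold lower number from compound 1 to compound 3 (1.00 log units; beyond the scatter) with the S drawing. The gain can be assigned to configuration alone because of this: the fact that compounds 2 and 3 differ only in the configuration as drawn

Open, from the compounds shown here alone, is whether a methyl group in place of trifluoromethyl at that ring carbon would keep the same preference for the S drawing. Also open, going by these compounds, is whether a larger group, such as an ethyl group, would be accepted there.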